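A few compounds are considered here, and "the series" means these few. Any claim that something is new, unique, unknown or untested is made for them only; others in the source may bear on it.

Working notes on the series at a functional assay on CHO cells for agonist activity at Free fatty acid receptor 1 (Homo sapiens), read by FLIPR and calcium flux, tested at 1 uM; on this read-out higher numbers stand for an effect only at larger amounts of compound and lower numbers for an effect already at smaller amounts.

Three members of the series have been run so far. Compound 1 `Cc1ccc(C)c(OCc2nnc(C(=O)Nc3ccc(CCC(=O)O)cc3)s2)c1` gives 1530 nM in this assay. Compound 2 `Cc1cccc(OCc2nnc(C(=O)Nc3ccc(CCC(=O)O)cc3)s2)c1` gives 3260 nM. Compound 3 `Cc1ccccc1OCc1nnc(C(=O)Nc2ccc(CCC(=O)O)cc2)s1` gives 1520 nM. On these numbers compound 1 stands second highest of the three: its nearest neighbour is compound 3, which lies within the scatter of it, and its furthest is compound 2, with a 2.1-fold higher number from compound 1 to compound 2 (0.33 log units; beyond the scatter). The step of a 1.0-fold lower number from compound 1 to compound 3 (0.00 log units; within the scatter) is within the scatter, whereas a 2.1-fold lower number from compound 2 to compound 3 (0.33 log units; beyond the scatter) is modest but beyond it.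

The next member is compound 4 `O=C(O)CCc1ccc(NC(=O)c2nnc(Cc3ccccc3)s2)cc1`. Relative to compound 1 the change is phenyl in place of 2,5-dimethylphenoxy on a saturated chain carbon bound to an aromatic carbon. The steps already in hand bear on it only in part: each of them removes a single methyl from the aromatic ring, or moves it, and none removes the oxygen or both methyls together. Taking one methyl away cost nothing beyond the scatter in a 1.0-fold lower number from compound 1 to compound 3 (0.00 log units; within the scatter) and a modest rise in a 2.1-fold higher number from compound 1 to compound 2 (0.33 log units; beyond the scatter); the present change takes away more, so a modest rise in this assay is expected, with wide uncertainty. The expected step is a 2.3-fold higher number from compound 1 to compound 4 (0.36 log units; beyond the scatter). For compound 4 the estimate in this assay is 3500 nM, with a range from 1200 nM to 10000 nM.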

Compound 4, half-maximal effective concentration: 3670 nM
Compound 4: the middle estimate sits 1.0-fold (0.02 log units) below what was measured; measured number inside the range.
By their numbers in this assay, from the lowest: compounds 3 and 1 (each within the scatter of the next); then compounds 2 and 4 (each within the scatter of the next).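

In this assay the saturated chain carbon bound to an aromatic carbon accepts the loss of the oxygen and the methyl groups together, a larger change than any single methyl step seen so far, at only a modest cost: a 2.4-fold higher number from compound 1 to compound 4 (0.38 log units; beyond the scatter) and likewise a 2.4-fold higher number from compound 3 to compound 4 (0.38 log units; beyond the scatter). The step of a 1.1-fold higher number from compound 2 to compound 4 (0.05 log units; within the scatter) lies within the scatter, so phenyl reads level with 3-methylphenoxy, and the two compounds carrying 2-methyl substitution, compound 1 and compound 3, stand apart from the two without it, compound 2 and compound 4, with none of the four going against this split. Nothing on hand accounts for these steps.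

The oxygen and the methyl groups leave together here, so their shares in the step cannot be separated, and an unsubstituted phenoxy or a 2-methylphenyl on the same carbon would be the direct test. Going by these compounds, whether a chloro or methoxy group on the ring, or a longer chain to the ring, would keep the lower numbers of compound 1 and compound 3 also stays open.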